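Opening a piperazine: compound 3 against compounds 1 and 2

The source may report more compounds than this note shows. Statements on the series, on what has been measured and on what is new or still open speak of the compounds shown alone.

Measured compounds:
Compound 1, `CCC(CC)N1CCN(c2nc3c(c(Nc4ccc(C(F)(F)F)cc4)n2)CCN(c2ncccc2C(F)(F)F)CC3)CC1`: 41 nM
Compound 2, `FC(F)(F)c1ccc(Nc2nc(N3CCN(C4CCC4)CC3)nc3c2CCN(c2ncccc2C(F)(F)F)CC3)cc1`: 24 nM

Both measurements come from a functional assay on HEK293 cells for antagonist activity at transient receptor potential cation channel subfamily V member 1 (Homo sapiens), read by FLIPR and calcium flux; on this read-out higher numbers stand for weaker inhibition and lower numbers for stronger inhibition. In this assay, for the measured compounds named here, compound 1 gives 41 nM and compound 2 gives 24 nM, and the only measured step between them, a 1.7-fold lower number from compound 1 to compound 2 (0.23 log units; within the scatter), places the two numbers within the usual scatter of each other. Compound 1 therefore stands alongside compound 2 rather than apart from it.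

Compound 3, `CN1CCCCC1CNc1nc2c(c(Nc3ccc(C(F)(F)F)cc3)n1)CCN(c1ncccc1C(F)(F)F)CC2`, has not yet been measured. It differs from compound 1 in one place: ((1-methylpiperidin-2-yl)methyl)amino in place of 4-(pentan-3-yl)piperazin-1-yl on an aromatic carbon. This is a different kind of change from the measured step, which only exchanged the substituent on the piperazine nitrogen; here the ring itself leaves and an amine bearing one hydrogen-bond donor enters. Going by the values given here, the single measured step thus bears on it only loosely and was itself within the scatter. Compound 3 is accordingly expected to show a modest step toward higher numbers, a 1.7-fold higher number from compound 1 to compound 3 (0.23 log units; within the scatter), one that may not exceed the scatter. The estimate for compound 3 is 70 nM, within a range from 20 nM to 300 nM.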

Compound 3, half-maximal inhibitory concentration: 1760 nM
Beside the measured number, compound 3's estimate is 25-fold (1.40 log units) below it; the whole stated range lies below it.
By their numbers in this assay, from the lowest: compounds 2 and 1 (each within the scatter of the next); then compound 3.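

In this assay the aromatic carbon between two ring nitrogen atoms proves far more sensitive than the piperazine nitrogen. Putting ((1-methylpiperidin-2-yl)methyl)amino in place of 4-(pentan-3-yl)piperazin-1-yl gives a 43-fold higher number from compound 1 to compound 3 (1.63 log units; beyond the scatter) and putting it in place of 4-cyclobutylpiperazin-1-yl gives a 73-fold higher number from compound 2 to compound 3 (1.87 log units; beyond the scatter) while the earlier exchange on the piperazine nitrogen stayed within the scatter. Among these three compounds, then, replacing the whole piperazine group at this position matters much more than changing the substituent it carries, but nothing measured here explains the loss.

The change replaces the piperazine ring with a piperidine ring on a methylene link and also adds an amino hydrogen, so the compounds shown cannot separate these features. From the compounds shown here alone, it remains open whether a tertiary amine such as N-methyl-N-((1-methylpiperidin-2-yl)methyl)amino, or a ring such as 4-methylhomopiperazin-1-yl or morpholin-4-yl, would stay close to compound 1 and compound 2 or would fall with compound 3.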